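The source may report more compounds than this note shows. Statements on the series, on what has been measured and on what is new or still open speak of the compounds shown alone.

Compound 3 `Nc1ccccc1NC(=O)c1ccc(COCNc2nc(Nc3ccccc3)c3ncn(C4CCCC4)c3n2)cc1` gives 37.5% in a functional assay on HepG2 cells (Homo sapiens) for antiproliferative activity, read by CCK-8 assay, with a stated time of 72 h, tested at 2 uM (a higher number here means a stronger effect of the compound at the concentration tested, a lower number a weaker effect), which places it second highest of the three measured numbers. Compound 2 `CC(C)n1cnc2c(NCc3ccc(C(=O)Nc4ccccc4N)cc3)nc(Cl)nc21` gives 63.8% in this assay, beyond the scatter above compound 3, and compound 1 `COC(CCn1cnc2c(NCc3ccc(C(=O)Nc4ccccc4N)cc3)nc(Cl)nc21)OC` gives 8.52%, beyond the scatter below it. Compound 4 `CCCCn1cnc2c(Nc3ccccc3)nc(NCOCc3ccc(C(=O)Nc4ccccc4N)cc3)nc21` differs from compound 3 in one place: butyl in place of cyclopentyl on an aromatic nitrogen. Among the measured compounds shown here, the only measured step that touches the same place, the group on the aromatic nitrogen of the fused core, is the one from compound 1 to compound 2, where a number 55.3 percentage points higher from compound 1 to compound 2 (beyond the scatter). That step shows the group at this position can matter a great deal, but it swaps an oxygen-bearing chain for a small branched group, whereas here one plain hydrocarbon group, cyclopentyl, is replaced by another, butyl, so it does not say in which direction compound 4 should move. For the measured compounds named here, with no closer precedent, compound 4 is expected to stay close to compound 3, with a step of about a number 5.5 percentage points lower from compound 3 to compound 4 (within the scatter), within the scatter. The estimate for compound 4 in this assay is therefore 32%, with a range from 12% to 55%.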

Compound 4, a percentage reported as inhibition, at one concentration (the size of the read-out at that concentration, not a potency): 46.6%
Compound 4: middle estimate off by 14.6 percentage points, on the low side, within the range that was stated.
By their numbers in this assay, from the lowest: compound 1; then compounds 3 and 4 (each within the scatter of the next); then compound 2.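

In this assay, replacing the cyclopentyl ring with the open butyl chain gives a number 9.1 percentage points higher from compound 3 to compound 4 (within the scatter), so compound 3 and compound 4 cannot be told apart. At this aromatic nitrogen, then, opening the ring and going from 5 to 4 carbon atoms leaves no change that stands out from the scatter, whereas the earlier step from compound 1 to compound 2 had shown only that a change here can have a large effect. No available measurement explains why these two hydrocarbon groups read alike.

The compounds shown leave open how far this tolerance extends: a longer chain such as octyl, or a chain ending in an amine or a carboxylic acid, might read quite differently. They also do not separate the effect of the oxygen atoms from that of the chain length in the 3,3-dimethoxypropyl group of compound 1.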